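The compounds below may be only part of what the source reports. "The series", "measured", "known", "first", "only" and "open" are said of these compounds alone.

In a functional assay on MDA-MB-435 cells (Homo sapiens) for cytotoxicity, read by MTT assay, with a stated time of 72 h (a higher number here means a weaker inhibitor, a lower number a stronger inhibitor), compound 1 `NCCCNc1c(C(=O)NCc2ccc(F)cc2)nc(Br)c2cccnc12` gives 5000 nM and compound 2 `N[C@H]1CC[C@H](Nc2c(C(=O)NCc3ccc(Cl)cc3Cl)nc(Br)c3cccnc23)CC1` gives 5800 nM. These two values lie within the scatter of each other. Compound 3 `C[C@H](NC(=O)c1nc(Br)c2cccnc2c1N[C@H]1CC[C@H](N)CC1)c1ccc(F)cc1` reaches only a limit, > 10000 nM.

The unmeasured compound 4 `NCCNc1c(C(=O)NCc2ccc(F)cc2)nc(Br)c2cccnc12` differs from compound 1 at one place, with amino in place of aminomethyl on a saturated chain carbon, two bonds along the chain from a nitrogen on an aromatic ring. The same difference reads as 3-aminopropyl to 2-aminoethyl.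

For the measured compounds named here, the only measured single-place step, an at least 1.7-fold higher number from compound 2 to compound 3 (0.23 log units; that floor lies within the scatter), lies on an amide-type nitrogen and not on this chain, so it offers no size to carry over. Going by the values given here, no measured step covers the chain change itself. With compound 1 at 5000 nM as the starting point, no step beyond the scatter is expected in this assay. The expected step is a 1.2-fold higher number from compound 1 to compound 4 (0.08 log units; within the scatter). The estimate for compound 4 is 6000 nM, with an expected range from 2000 nM to 10000 nM.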

Compound 4, half-maximal inhibitory concentration: 12000 nM
Beside the measured number, compound 4's estimate is 2.0-fold (0.30 log units) below it, outside the stated range (above it).
By their numbers in this assay, from the lowest: compounds 1 and 2 (each within the scatter of the next); then compound 4.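

In this assay the chain on the shared core proves sensitive to length: going from 3-aminopropyl to 2-aminoethyl gives a 2.4-fold higher number from compound 1 to compound 4 (0.38 log units; beyond the scatter) and so a modest step beyond the scatter. The earlier single-place step lay on an amide-type nitrogen, with a floor within the scatter, so this chain is the only place in the compounds shown where one change clearly moves the number. The number for compound 4 also falls in the region where this assay gives a limit for another compound of the series: the limit of > 10000 nM in this assay, at which 1 of the 4 values shown sits.

Going by these compounds, whether a longer chain such as 4-aminobutyl would follow the same direction remains open. Also open, on these data alone, is whether the end amine matters in itself, which a hydroxyl or a dimethylamino group on the 3-aminopropyl chain could test.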